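A few compounds are considered here, and "the series" means these few. Any claim that something is new, unique, unknown or untested is made for them only; others in the source may bear on it.

Of the compounds shown here, three sharing one core have been measured in an ADME assay on Vero cells (Chlorocebus sabaeus) for cytotoxicity, read by fluorescence, with a stated time of 4 days; a lower number here means a stronger inhibitor, a higher number a weaker inhibitor. Compound 1 `CC(C)(CNC(=O)c1ccc2ccccc2c1O)CC1=C(O)C(=O)c2ccccc2C1=O` gives 93700 nM, compound 2 `COc1c(C(=O)NCC(C)(C)CC2=C(O)C(=O)c3ccccc3C2=O)ccc2ccccc12` gives 47300 nM, and compound 3 `COc1cc(C(=O)NCC(C)(C)CC2=C(O)C(=O)c3ccccc3C2=O)c(O)c2ccccc12` gives 15800 nM, the lowest number of the three. Compound 4 `COc1cc(C(=O)NCC(C)(C)CC2=C(O)C(=O)c3ccccc3C2=O)c(OC)c2ccccc12` differs from compound 3 by methyl in place of hydrogen on an oxygen on an aromatic ring, the same difference that separates compound 1 from compound 2, a pair for which a 2.0-fold lower number from compound 1 to compound 2 (0.30 log units; within the scatter) was observed. The other known step, a 5.9-fold lower number from compound 1 to compound 3 (0.77 log units; beyond the scatter), concerns a different change and bears on this one only loosely. The shift from this change is therefore expected to be small, a 1.6-fold lower number from compound 3 to compound 4 (0.20 log units; within the scatter), staying within the scatter and leaning lower. Compound 4 is expected to give about 10000 nM in this assay, in the range from 3500 nM to 30000 nM.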

Compound 4, half-maximal inhibitory concentration: 17700 nM
Compound 4: middle estimate off by 1.8-fold (0.25 log units), on the low side; the range from low to high includes it.
By their numbers in this assay, from the lowest: compounds 3 and 4 (each within the scatter of the next); then compounds 2 and 1 (each within the scatter of the next).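

In this assay, the change from hydroxy to methoxy on this oxygen stays within the scatter on a second core, with a 1.1-fold higher number from compound 3 to compound 4 (0.05 log units; within the scatter), and the two cores agree: the same change on two cores in this assay, a 2.0-fold lower number (0.30 log units; within the scatter) from compound 1 to compound 2 and a 1.1-fold higher number (0.05 log units; within the scatter) from compound 3 to compound 4, 2.2-fold (0.35 log units) apart, within the scatter of two such steps. Methoxy in place of hydrogen on an aromatic carbon also stays beyond the scatter when this oxygen already carries methyl, with a 2.7-fold lower number from compound 2 to compound 4 (0.43 log units; beyond the scatter), and that change likewise agrees across the two cores: the same change on two cores in this assay, a 5.9-fold lower number (0.77 log units; beyond the scatter) from compound 1 to compound 3 and a 2.7-fold lower number (0.43 log units; beyond the scatter) from compound 2 to compound 4, 2.2-fold (0.35 log units) apart, within the scatter of two such steps.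

As far as these compounds go, whether an ethyl group or a longer chain on this oxygen would also stay within the scatter remains open, as does the outcome for a chain ending in an amine.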